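A few compounds are considered here, and "the series" means these few. Any claim that something is new, unique, unknown or untested is made for them only; others in the source may bear on it.

Measured compounds:
compound 1 `Cn1c(CN2CCN(c3ccc(C(F)(F)F)cn3)CC2)nc2ccccc21` — 81%
compound 2 `Cn1c(CN2CCN(c3ccccn3)CC2)nc2ccccc21` — 100%

In an assay on CHO cells with metabotropic glutamate receptor 2 (Homo sapiens) as the target, read by FLIPR (a higher number here means a larger maximal response, a lower number a smaller maximal response), compound 1 gives 81%, the lowest of the two numbers; its nearest neighbour, compound 2, gives 100%. Going by the values given here, the only step measured is a number 19 percentage points higher from compound 1 to compound 2 (beyond the scatter), which shows that taking the trifluoromethyl off the ring raised the maximal response beyond the scatter.

Compound 3 `Cn1c(CN2CCN(c3ncc(C(F)(F)F)cc3Cl)CC2)nc2ccccc21` differs from compound 1 by chloro in place of hydrogen on an aromatic carbon. Among the compounds with values here, no measured step involves a chloro group, so the direction of this change is not fixed by the data. Within the data shown here, the one step that bears on it only indirectly, a number 19 percentage points higher from compound 1 to compound 2 (beyond the scatter), shows that a more heavily substituted ring gave the smaller response, so a further substituent is expected to leave the number near that of compound 1 or somewhat lower.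

For compound 3 the maximal response in this assay is estimated at 75%, within 55% to 95%, a step of a number 6 percentage points lower from compound 1 to compound 3 (within the scatter) that is expected to stay within the scatter.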

Compound 3, largest response reached (Emax), in percent of the reference or control that the assay uses: 71%
Beside the measured number, compound 3's estimate is 4 percentage points above it, and the stated range covers the measured number.
By their numbers in this assay, from the lowest: compounds 3 and 1 (each within the scatter of the next); then compound 2.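

In this assay, a number 10 percentage points lower from compound 1 to compound 3 (within the scatter), so chloro on this aromatic carbon, ortho to a large group and meta to a trifluoromethyl group, leaves the maximal response indistinguishable from that of compound 1. Going by these compounds alone, the earlier step concerned only the trifluoromethyl group, whereas this one is the first measured change at this position, and it was made with the trifluoromethyl group kept in place. No measurement here accounts for the result in terms of any property of the chloro group.

The compounds shown leave open whether chloro would behave the same way on a ring without the trifluoromethyl group. They also leave open whether a methyl group, a methoxy group, a nitrile or an amine at this position would stay within the scatter of compound 1.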